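The compounds below may be only part of what the source reports. "The series", "measured", "known", "first", "only" and "open" are said of these compounds alone.

Of the compounds shown here, two with a shared core have been tested so far in an ADME assay on MCF7 cells (Homo sapiens) for cytotoxicity, read by MTT assay, with a stated time of 48 h; on this read-out higher numbers stand for weaker inhibition and lower numbers for stronger inhibition. Compound 1 (`COc1ccc2c(Cn3ccnc3)c(-c3ccc(Cl)cc3)[nH]c2c1`) reports > 1000000 nM, which is a limit of the assay and not a number. Among the measured compounds shown here, compound 2 (`COc1ccc2c(Cn3cncn3)c(-c3ccc(F)cc3)[nH]c2c1`) gives 12200 nM, the only true number so far, so there is no measured neighbour to rank it against. Compound 3 (`COc1ccc2c(Cn3cncn3)c(-c3ccc(Cl)cc3)[nH]c2c1`) differs from compound 2 in one place: chloro in place of fluoro on an aromatic carbon, para to a large group, which turns 4-fluorophenyl into 4-chlorophenyl (chloro in place of fluoro on an aromatic carbon). For the measured compounds named here, no measured pair of compounds isolates this swap, so the data give no direct size for it. Compound 1 also carries the 4-chlorophenyl but differs from compound 3 elsewhere, so it gives no measure of this swap either. Starting from the 12200 nM of compound 2, the expectation is therefore no shift beyond the usual scatter. The expected step of a 1.1-fold higher number from compound 2 to compound 3 (0.06 log units; within the scatter) is small. Compound 3 is estimated at 14000 nM, with an expected range of 4000 nM to 60000 nM.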

Compound 3, half-maximal inhibitory concentration: 612000 nM
Compound 3: the middle estimate sits 44-fold (1.64 log units) below what was measured; measured number above the stated range.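

The halogen on this phenyl ring, on the aromatic carbon para to a large group, proves to matter a great deal in this assay: going from 4-fluorophenyl to 4-chlorophenyl exchanges one heavy atom for one heavy atom, with the rest of the molecule unchanged, yet gives a 50-fold higher number from compound 2 to compound 3 (1.70 log units; beyond the scatter). With the chlorophenyl kept in place, 1H-1,2,4-triazol-1-yl in place of 1H-imidazol-1-yl on the saturated chain carbon gives an at least 1.6-fold lower number from compound 1 to compound 3 (0.21 log units; that floor lies within the scatter), so this pair shows no change beyond the scatter. That step is only a floor and its true size stays unknown, because compound 1 is a limit and not a number: the limit of > 1000000 nM in this assay, at which 1 of the 3 values shown sits.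

Going by these compounds, what a plain hydrogen, a methyl or a methoxy group would give on this same ring carbon stays open, and two halogens alone do not make a trend. Also open, on these data alone, is whether the large step from fluoro to chloro holds with 1H-imidazol-1-yl on the chain, which would take a 4-fluorophenyl partner of compound 1 to tell.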